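Replacing one group in compound 3

The source may report more compounds than this note shows. Statements on the series, on what has been measured and on what is new or still open speak of the compounds shown alone.

Compound 1 `O=C1COCCN1c1ccc(C2CC(c3ccc([N+](=O)[O-])o3)=NO2)cn1` gives 86.1 nm/s
Compound 2 `O=[N+]([O-])c1ccc(C2=NOC(c3ccc(N4CCCCC4)cc3)C2)o1` gives 76.1 nm/s
Compound 3 `O=C1COCCN1c1ccc(C2CC(c3ccc([N+](=O)[O-])o3)=NO2)cc1F` gives 154 nm/s

These three numbers all come from an ADME assay on Caco-2 cells (Homo sapiens) for permeability, read by HPLC, with a stated time of 2 h (a lower number here means that the compound crosses the layer more slowly, a higher number that the compound crosses the layer faster), and show how far the compounds spread. Compound 3 stands within the scatter of compound 1 and just beyond the scatter above compound 2. Compound 4 `CN1CCN(c2ccc(C3CC(c4ccc([N+](=O)[O-])o4)=NO3)cc2F)C(=O)C1` has 4-methyl-2-oxopiperazin-1-yl in place of 3-oxomorpholin-4-yl on an aromatic carbon. Going by the values given here, no measured pair shows this swap. Compound 2 (at 76.1 nm/s) carries neither group, yet the gap to compound 3 (at 154 nm/s) is small. The expected step in this assay is small and downward (a 1.3-fold lower number from compound 3 to compound 4 (0.13 log units; within the scatter)) and within the scatter. For compound 4 the estimate is 115 nm/s (expected range 55 nm/s to 230 nm/s).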

Compound 4, apparent permeability: 270 nm/s
Compound 4: the middle estimate sits 2.3-fold (0.37 log units) below what was measured; the whole stated range lies below it.
By their numbers in this assay, from the lowest: compounds 2, 1, 3 and 4 (each within the scatter of the next, the first and the last beyond it).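

In this assay, placing 4-methyl-2-oxopiperazin-1-yl in place of 3-oxomorpholin-4-yl gives a 1.8-fold higher number from compound 3 to compound 4 (0.24 log units; within the scatter), so this position, on an aromatic carbon ortho to a fluoro group, accepts the larger ring without a step beyond the scatter. Nothing shown accounts for the size of this step. Still open, from the compounds shown here alone, is whether a piperazin-1-yl ring without the methyl, or a carboxylic acid, would also stay within the scatter here. Also open, going by these compounds, is whether the same swap on the core of compound 1 would give a similar step.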